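A few compounds are considered here, and "the series" means these few. Any claim that something is new, unique, unknown or untested is made for them only; others in the source may bear on it.

Measured so far in an assay for inhibition of methylcytosine dioxygenase TET2 (Homo sapiens), read by mass spectrometry, with stated times of 30 min and 1 h; on this read-out higher numbers stand for weaker inhibition and lower numbers for stronger inhibition:
compound 1, `O=S(=O)(Nc1ccccc1)c1ccc(F)c2ncc(I)cc12`: 23900 nM
compound 2, `O=S(=O)(Nc1cccc(O)c1)c1ccc(F)c2ncc(I)cc12`: > 200000 nM, which is a limit of the assay

Compound 2 therefore stands at the limit of this assay, with no number of its own (the limit of > 200000 nM in this assay, at which 1 of the 2 values shown sits). From compound 2 to compound 3, `COc1cccc(NS(=O)(=O)c2ccc(F)c3ncc(I)cc23)c1`, the change is methyl in place of hydrogen on an oxygen on an aromatic ring. For the measured compounds named here, the only measured step, an at least 8.3-fold higher number from compound 1 to compound 2 (0.92 log units; beyond the scatter), bears on it just loosely, since it introduced the hydroxy that compound 3 now carries as methoxy. Nothing measured shows what that methyl does, so no step beyond the scatter is expected, and compound 3 is expected at a number no higher from compound 2 to compound 3 (the limit leaves the size open). Compound 3 is estimated at 200000 nM, between 50000 nM and 600000 nM, and may well again read only as a limit in this assay.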

Compound 3, half-maximal inhibitory concentration: > 200000 nM
Compound 3 ended at the assay's limit; the forecaster's own chance of this, stated with the estimate: 60%; the middle value lies on the limit itself.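

In this assay, compound 3 gives > 200000 nM, which is a limit of the assay. A free hydroxy is therefore not needed for the loss at this place, as methoxy also leaves compound 1's readable value behind, with an at least 8.3-fold higher number from compound 1 to compound 3 (0.92 log units; beyond the scatter). The step between hydroxy and methoxy cannot be read, and the two groups cannot be ranked: the limit of > 200000 nM in this assay, at which 2 of the 3 values shown sit.

From the compounds shown here alone, whether an amine or a carboxylic acid on this aromatic carbon would keep a readable number, as hydrogen does in compound 1, stays open. Going by these compounds, how far compound 2 and compound 3 truly lie beyond the limit also stays open.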